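Methyl for Methoxy on a Poorly Soluble Core

The source may hold more compounds than are shown below. What is called first, only, known or untested is meant among the compounds shown, and "the series" means these compounds.

Compound 1 `Cc1c(COc2cccc(OCC3CCOCC3)c2)[nH]c2ccc(-c3cccnc3)cc2c1=O` sits at a limit in a physicochemical assay for solubility, at pH 6.8; on this read-out higher numbers stand for higher solubility and lower numbers for lower solubility: compound 1 gives < 1000 nM, a bound of the assay rather than a number. Compound 2 `COc1ccc2[nH]c(COc3cccc(OCC4CCOCC4)c3)c(C)c(=O)c2c1` likewise gives only a limit, < 1000 nM, in this assay. Compound 3 `Cc1c(COc2cncc(OCCC(C)(C)O)c2)[nH]c2ccccc2c1=O`, which differs from the other two in several places, gives >= 100000 nM in this assay, a limit at the opposite end of the scale. Among the measured compounds shown here, the single step between one-change neighbours, a step that the two limits leave unreadable from compound 1 to compound 2, cannot be sized, since both of its ends rest on (the limit of < 1000 nM in this assay, at which 2 of the 3 values shown sit); compound 3 alone rests on (the limit of >= 100000 nM in this assay, at which 1 of the 3 values shown sits).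

Compound 4 `Cc1ccc2[nH]c(COc3cccc(OCC4CCOCC4)c3)c(C)c(=O)c2c1` differs from compound 2 as follows: methyl in place of methoxy on an aromatic carbon. For the measured compounds named here, no measured step of this kind is available, and the only neighbouring step, a step that the two limits leave unreadable from compound 1 to compound 2, is unreadable. With both parents of the shared core at the same limit, there is no ground for expecting this small change to lift compound 4 clear of it. The step that the limit leaves unreadable from compound 2 to compound 4 is therefore expected to be none beyond the scatter. Compound 4 is estimated at 500 nM, within a range from 100 nM to 3000 nM, most probably reported again only as a limit.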

Compound 4, solubility: < 1000 nM
Compound 4 was reported as a limit; the forecaster's own chance of this, stated with the estimate: 75%; the middle value lies beyond the limit too.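

Compound 4 gives < 1000 nM in this assay, a limit of the assay and not a number. The steps to compound 4 from compound 1 and compound 2 therefore cannot be read: the limit of < 1000 nM in this assay, at which 3 of the 4 values shown sit. The compounds shown leave open how far methyl, methoxy and pyridin-3-yl on the shared core truly differ in this assay.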